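The source may report more compounds than this note shows. Statements on the series, on what has been measured and on what is new or still open speak of the compounds shown alone.

Compounds measured so far in a functional assay on PA-1 cells (Homo sapiens) for cytotoxicity, read by MTT assay, with stated times of 6 h and 48 h; a lower number here means a stronger inhibitor, a higher number a weaker inhibitor:

- compound 1 `Cn1c(/C=C/C(=O)c2ccccc2O)cc(Br)c1Br` gives 1250 nM
- compound 2 `Cn1c(/C=C/C(=O)c2ccccc2)cc(Br)c1Br` gives >= 100000 nM as a limit of the assay, not a number
- compound 3 `COc1ccc(C(=O)/C=C/c2cc(Br)c(Br)n2C)c(OC)c1` gives 520 nM

Of the two actual numbers, compound 3 at 520 nM stands lowest, while compound 1 at 1250 nM lies higher, a gap beyond the scatter.

Compound 4 `COc1ccc(C(=O)/C=C/c2cc(Br)c(Br)[nH]2)c(OC)c1` has not yet been measured. Its difference from compound 3 is hydrogen in place of methyl on an aromatic nitrogen, counted as hydrogen in place of methyl on an aromatic nitrogen and with nothing else altered.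

Going by the values given here, no measured step involves this nitrogen. Among the compounds with values here, the only measured step, an at least 80-fold higher number from compound 1 to compound 2 (1.90 log units; beyond the scatter) and hydrogen in place of hydroxy on an aromatic carbon, is a large one, but it is a different change and ends at a limit: the limit of >= 100000 nM in this assay, at which 1 of the 3 values shown sits, and so it gives no direct guide here.

With compound 3 at 520 nM as the only close reference, the expected step is modest, a 1.3-fold higher number from compound 3 to compound 4 (0.13 log units; within the scatter) and its direction is uncertain. For compound 4 the estimated value is 700 nM with an expected range from 150 nM to 3500 nM in this estimate.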

Compound 4, half-maximal inhibitory concentration: 320 nM
Compound 4: middle estimate off by 2.2-fold (0.34 log units), on the high side, within the range that was stated.
By their numbers in this assay, from the lowest: compounds 4 and 3 (each within the scatter of the next); then compound 1. At a limit, above all of these: compound 2.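

In this assay, the methyl on the aromatic nitrogen gives way to hydrogen, and the outcome is a 1.6-fold lower number from compound 3 to compound 4 (0.21 log units; within the scatter) for this one change. The earlier compounds shown here all carry the methyl on this nitrogen, so they could not say whether it matters; this pair shows that, on the core of compound 3, losing the methyl leaves the number within the scatter. Nothing shown offers a reason for this result.

The compounds shown leave open what an ethyl group, a longer chain or an acetyl group on this nitrogen would do, since only methyl and hydrogen appear there. On these data alone, it is also open whether the same swap would behave alike on the core of compound 1, which carries a hydroxy group on its other aromatic ring.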